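Urea substituent changes and cytotoxicity in the shared core series

This account rests on a few compounds, and the source may have more. Where it says the series, first, only, none or still open, it means among the compounds named here.

Measured so far:
- compound 1 `CCN(CC)C(=O)NCCCC(C)Nc1cc(OC)cc2cccnc12`: > 100000 nM
- compound 2 `COc1cc(NC(C)CCCNC(=O)NCc2ccncc2)c2ncccc2c1`: 100000 nM
- compound 3 `COc1cc(NC(C)CCCNC(=O)N(C2CCCCC2)C2CCCCC2)c2ncccc2c1`: 4000 nM

In an ADME assay on HEL cells (Homo sapiens) for cytotoxicity (a higher number here means that more compound is tolerated, a lower number that less compound is tolerated), compound 1 gives only a limit, > 100000 nM, not a number. In this assay compound 2 gives 100000 nM, the highest of the two numbers obtained so far. Compound 3, carrying dicyclohexylamino on the carbonyl carbon, gives 4000 nM in this assay, a lower number, so more of the series is tolerated when the urea nitrogen carries the smaller ((pyridin-4-yl)methyl)amino group than the two cyclohexyl rings.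

Compound 4 `COc1cc(NC(C)CCCNC(=O)NC2CCCC2)c2ncccc2c1` differs from compound 2 in one place: cyclopentyl in place of (pyridin-4-yl)methyl on an amide-type nitrogen. Within the data shown here, the only step measured that touches this position is a number no higher from compound 1 to compound 2 (the limit leaves the size open), and since compound 1 sits at a limit of > 100000 nM in this assay, at which 1 of the 3 values shown sits, its size cannot be read. Compound 3 shows that bulkier carbon rings on this nitrogen go with a lower number, while a single cyclopentyl ring is smaller than two cyclohexyl rings.

The step is therefore expected to be downward but modest, a 2.5-fold lower number from compound 2 to compound 4 (0.40 log units; beyond the scatter), and compound 4 is estimated at 40000 nM in this assay, most likely between 10000 nM and 100000 nM.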

Compound 4, minimum cytotoxic concentration: 100000 nM
Compound 4: the middle estimate sits 2.5-fold (0.40 log units) below what was measured; the range from low to high includes it.
By their numbers in this assay, from the lowest: compound 3; then compounds 2 and 4 (each within the scatter of the next).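

In this assay, cyclopentyl in place of (pyridin-4-yl)methyl on an amide-type nitrogen gives no change at the digits printed from compound 2 to compound 4 (within the scatter), so this change does not separate the pair, and the six-membered aromatic ring of (pyridin-4-yl)methyl is not required to keep this level of tolerance. Among these compounds, compound 3, with dicyclohexylamino on the carbonyl carbon, remains the only compound with a lower number, at 4000 nM, so a single carbon ring on this nitrogen does not by itself go with that drop. With cyclopentylamino in place of diethylamino on a carbonyl carbon, the data show a number no higher from compound 1 to compound 4 (the limit leaves the size open). The steps from compound 1 cannot be read because its value is a limit: the limit of > 100000 nM in this assay, at which 1 of the 4 values shown sits.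

Open, as far as these compounds go, is whether a single cyclohexyl ring on this nitrogen stays with compound 4 or moves toward compound 3, which would help separate ring size from ring number. Also open, from the compounds shown here alone, is whether a longer chain ending in a carboxylic acid or an amine keeps the number seen for compound 2.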